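The source may hold more compounds than are shown below. What is called first, only, known or untested is meant among the compounds shown, and "the series" means these compounds.

Compound 1, `COc1ccc2cc(C(C)c3nnc4n3N=C(c3ccc(OC(F)(F)F)cc3)CS4)ccc2c1`, gives 11700 nM in a functional assay on HCT-116 cells (Homo sapiens) for inhibition, read by sulforhodamine B assay, with a stated time of 72 h; a higher number here means a weaker inhibitor, a lower number a stronger inhibitor.
Compound 2, `COc1ccc2cc(C(C)c3n[nH]c(=S)n3N)ccc2c1`, gives 20200 nM in this assay.

Of these two numbers, compound 1 has the lower one, but its gap to compound 2 is within the scatter of repeated measurements, so the two compounds cannot be set apart on these values. Compound 3, `COc1ccc2cc(C(C)c3nnc4n3N=C(c3ccc(Cl)cc3)CS4)ccc2c1`, has not yet been measured. It differs from compound 1 in one place: chloro in place of trifluoromethoxy on an aromatic carbon. Among the measured compounds shown here, no measured pair of compounds shows the effect of this particular change, so there is nothing to build a firm expectation on. For the measured compounds named here, with the shared core unchanged and only one group on the outer ring swapped, the step from compound 1 to compound 3 is expected to stay within the scatter, a 1.0-fold higher number from compound 1 to compound 3 (0.01 log units; within the scatter), with no clear direction. For compound 3 in this assay the estimate is 12000 nM, most likely falling between 5000 nM and 30000 nM.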

Compound 3, half-maximal inhibitory concentration: 8800 nM
The estimate for compound 3 lay 1.4-fold (0.13 log units) above the measured number, and the stated range covers the measured number.
By their numbers in this assay, from the lowest: compounds 3, 1 and 2 (each within the scatter of the next, the first and the last beyond it).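

In this assay, among the compounds shown here, the swap of 4-(trifluoromethoxy)phenyl for 4-chlorophenyl gives the first direct reading of a single change at this position on the outer ring (a 1.3-fold lower number from compound 1 to compound 3 (0.12 log units; within the scatter)). The group shrinks from 5 heavy atoms to 1 heavy atom and gives up its hydrogen-bond acceptor, yet the two compounds cannot be set apart, so this pair shows that the position accepts either group with no readable difference in this assay. Nothing measured on these compounds speaks to why the exchange leaves the reading within the scatter.

Still open, as far as these compounds go, is whether an amine, a carboxylic acid or a longer chain at this position would move the number beyond the scatter. Equally open, from the compounds shown here alone, is what plain hydrogen there, with no group at all, would give.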